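Amino series: dimethylamino to diethylamino

The source may report more compounds than this note shows. Statements on the series, on what has been measured and on what is new or still open speak of the compounds shown alone.

Values in a functional assay on HeLa cells (Homo sapiens) for antiproliferative activity, read by cell counting, with a stated time of 2 days; on this read-out lower numbers stand for stronger inhibition and higher numbers for weaker inhibition:
- compound 1 `COc1cc(C(=O)c2sc(N)nc2N)cc(OC)c1OC`: 31000 nM
- compound 2 `COc1cc(C(=O)c2sc(N(C)C)nc2N)cc(OC)c1OC`: 8200 nM

Of these two numbers, compound 2 holds the lower, at 8200 nM. Compound 3 `CCN(CC)c1nc(N)c(C(=O)c2cc(OC)c(OC)c(OC)c2)s1` carries diethylamino in place of dimethylamino on an aromatic carbon, (diethylamino in place of dimethylamino on an aromatic carbon). Going by the values given here, only one measured step bears on this change: a 3.8-fold lower number from compound 1 to compound 2 (0.58 log units; beyond the scatter), a modest step that came with dimethylamino in place of amino on the same carbon. Among the compounds with values here, a single step sets no trend, and no measured compound carries a group larger than dimethylamino there. A small further fall in this assay is therefore expected, possibly none beyond the scatter. The estimated result is a 1.4-fold lower number from compound 2 to compound 3 (0.14 log units; within the scatter). For compound 3 the estimate is 6000 nM, with an expected range of 1800 nM to 20000 nM.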

Compound 3, half-maximal inhibitory concentration: 38000 nM
The estimate for compound 3 lay 6.3-fold (0.80 log units) below the measured number; the measured number lies above the stated range.
By their numbers in this assay, from the lowest: compound 2; then compounds 1 and 3 (each within the scatter of the next).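

In this assay the change from dimethylamino to diethylamino gives a 4.6-fold higher number from compound 2 to compound 3 (0.67 log units; beyond the scatter) and so runs against the earlier 3.8-fold lower number from compound 1 to compound 2 (0.58 log units; beyond the scatter) at this same aromatic carbon. Diethylamino and amino are not separated, with a 1.2-fold higher number from compound 1 to compound 3 (0.09 log units; within the scatter) within the scatter, so across these three compounds the number does not move steadily with the size of the group, and only compound 2 stands apart with the lowest number. No measured evidence accounts for this turn at the position.

Still open is how narrow the preference for dimethylamino is, since the shared core is shown here with only amino, dimethylamino and diethylamino at this carbon. Methylamino, ethylamino or a ring amine such as pyrrolidine or morpholine at the same carbon have not been measured. Values for them would show whether the number also rises with groups other than diethylamino.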